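Compound 3 to compound 4: a step behind limits

The compounds below may be only part of what the source reports. "The series", "measured", "known", "first", "only" and "open" are said of these compounds alone.

Values in a functional assay on Raji cells (Homo sapiens) for cytotoxicity, with a stated time of 72 h; on this read-out higher numbers stand for an effect only at larger amounts of compound and lower numbers for an effect already at smaller amounts (each one a limit, not a number):
- compound 1 (`C=C[C@@](C)(/C=C/c1ccc(O)cc1)CCC(O)C(C)(C)O`) gives > 26000 nM
- compound 2 (`C=C[C@@](C)(/C=C/c1ccc(O)cc1)CCCO`) gives > 26000 nM
- compound 3 (`C=C[C@@](C)(/C=C/c1ccc(O)cc1)CC/C=C(C)/C=N/N`) gives > 26000 nM

Compound 3 stands at > 26000 nM and this is a limit. The series offers only the limit of > 26000 nM in this assay, at which 3 of the 3 values shown sit, as its evidence. Compound 4 (`C=C[C@@](C)(/C=C/c1ccc(O)cc1)CC/C=C(\C)CO`) differs from compound 3 in one place (a group of 2 heavy atoms (1 carbon, 1 oxygen; no ring) in place of a group of 3 heavy atoms (1 carbon, 2 nitrogen; no ring), on a double-bonded chain carbon bound to a double-bonded chain carbon and a saturated chain carbon) and keeps the shared core. Among the measured compounds shown here, the steps that bear on this are a step that the two limits leave unreadable from compound 1 to compound 3 and a step that the two limits leave unreadable from compound 2 to compound 3 and neither has a readable size. No step beyond the scatter can therefore be argued for in this assay and the expected step is a number no higher from compound 3 to compound 4 (the limit leaves the size open) with no direction foreseen. For compound 4 the estimated value is 26000 nM with an expected range from 13000 nM to 52000 nM and another report as a limit is expected.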

Compound 4, half-maximal effective concentration: > 26000 nM
Compound 4 gave a limit, no number; the forecaster's own chance of this, stated with the estimate: 85%; the middle value lies on the limit itself.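

In this assay compound 4 gives > 26000 nM, a limit and not a number, and the steps to it from compound 1, compound 2 and compound 3 cannot be read. The compounds shown leave open how far apart they truly lie, and which change, if any, would give a measurable number: the limit of > 26000 nM in this assay, at which 4 of the 4 values shown sit.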